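Methyl in place of a phenolic hydrogen: what follows

A few compounds are considered here, and "the series" means these few. Any claim that something is new, unique, unknown or untested is made for them only; others in the source may bear on it.

Measured so far, in a physicochemical assay on cells (Homo sapiens), with a stated time of 18 h, tested at 10 uM; a lower number here means a stronger effect, a higher number a weaker effect of the compound at the concentration tested:
- compound 1, `COc1cc(/C=N/NC(=O)OCc2ccccc2)cc(OC)c1O`: 3%
- compound 2, `COc1cc(/C=N/Nc2nc3ccccc3s2)cc(OC)c1O`: 3%
- compound 3, `COc1cc(/C=N/NC(=O)OCc2ccccc2)cc(OC)c1OC`: 100%

Compound 1 and compound 2 share one side of the molecule but differ on the other; the difference between the two cores is not broken down here, and in this assay their numbers sit level with each other. Compound 3 is compound 1 after one change, (methyl in place of hydrogen on an oxygen on an aromatic ring), and that single step moved the read-out a number 97 percentage points higher from compound 1 to compound 3 (beyond the scatter). Compound 4, `COc1cc(/C=N/Nc2nc3ccccc3s2)cc(OC)c1OC`, is compound 2 after the same change, (methyl in place of hydrogen on an oxygen on an aromatic ring), at the same place described in the same words. Among the compounds with values here, because the only measured example of this step is a number 97 percentage points higher from compound 1 to compound 3 (beyond the scatter), a step of about a number 92 percentage points higher from compound 2 to compound 4 (beyond the scatter) is expected from compound 2 to compound 4. Compound 4 is therefore estimated at 95%, likely between 70% and 100%, though this rests on a single precedent and compound 4 itself is not yet measured.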

Compound 4, a percentage reported as activity, at one concentration (the size of the read-out at that concentration, not a potency): 14%
Beside the measured number, compound 4's estimate is 81 percentage points above it, outside the stated range (below it).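

In this assay, the change from hydroxy to methoxy moved the read-out a number 97 percentage points higher from compound 1 to compound 3 (beyond the scatter) on one core and a number 11 percentage points higher from compound 2 to compound 4 (beyond the scatter) on the other, so its direction carried over but its size did not. This shows that the core can strongly alter what the same change does, but two pairs give no rule for any further core. Nothing shown here explains why the two steps differ in size.

The compounds shown leave open what a longer chain on that oxygen, such as ethyl, would do on either core. They also leave open whether an amine in place of the hydroxy would behave like the hydroxy or the methoxy.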